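Amino Gives Way to Cyano: What Compound 3 May Show

A few compounds are considered here, and "the series" means these few. Any claim that something is new, unique, unknown or untested is made for them only; others in the source may bear on it.

Compound 1 `COC(=O)c1ccccc1-c1cnc(C(=O)CCCCCCc2ccccc2)o1` gives 60 nM in an assay (Rattus norvegicus) for inhibition of Fatty-acid amide hydrolase 1 (Homo sapiens); on this read-out lower numbers stand for stronger inhibition and higher numbers for weaker inhibition.
Compound 2 `Nc1cccc(-c2cnc(C(=O)CCCCCCc3ccccc3)o2)c1` gives 19 nM in this assay.

Of the two measured compounds, compound 2 stands at the lower number in this assay; the nearest value, that of compound 1, lies higher by a margin beyond the usual scatter. Compound 3 `N#Cc1cccc(-c2cnc(C(=O)CCCCCCc3ccccc3)o2)c1` has not yet been measured. It differs from compound 2 in one place: cyano in place of amino on an aromatic carbon. For the measured compounds named here, no step between measured compounds illuminates this exchange, so the expectation rests on compound 2 alone. The step from compound 2 to compound 3 in this assay is expected to be small, most likely a slight rise in the number, of the order of a 1.6-fold higher number from compound 2 to compound 3 (0.20 log units; within the scatter), and possibly nothing beyond the scatter. Compound 3 is therefore expected to give about 30 nM in this assay, within a range from 10 nM to 90 nM.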

Compound 3, inhibition constant: 15 nM
For compound 3 the middle estimate is 2.0-fold (0.30 log units) above the measured one, within the range that was stated.
By their numbers in this assay, from the lowest: compounds 3 and 2 (each within the scatter of the next); then compound 1.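

In this assay the exchange of amino for cyano amounts to a 1.3-fold lower number from compound 2 to compound 3 (0.10 log units; within the scatter), so on this read-out the 3-aminophenyl and 3-cyanophenyl forms cannot be told apart. Amino carries a hydrogen-bond donor and cyano carries none, and cyano brings one more heavy atom, yet in this pair neither difference shows in the read-out at this position on the six-membered aromatic ring. Nothing among the data shown explains why the two groups read alike.

From the compounds shown here alone, whether a carboxylic acid, a primary amide or a dimethylamino group at this same position would also stay within the scatter remains open. Compound 1 differs from compound 2 in more than one place, so it cannot show what this position alone contributes.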